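A few compounds are considered here, and "the series" means these few. Any claim that something is new, unique, unknown or untested is made for them only; others in the source may bear on it.

Measured in an assay on isolated protein for agonist activity at Bile acid receptor (Homo sapiens), read by FRET; on this read-out lower numbers stand for smaller maximal responses and higher numbers for larger maximal responses:
compound 1 `O=C(O)c1ccc(C2CC2c2ccc(OCc3c(-c4c(Cl)cccc4Cl)noc3C3CC3)cc2Cl)cn1` gives 101%
compound 2 `Cn1nc(C(=O)O)c2ccc([C@H]3C[C@](O)(c4ccc(OCc5c(-c6c(Cl)cccc6Cl)noc5C5CC5)cc4Cl)C3)cc21` gives 99%
compound 3 `O=C(O)c1cccc([C@H]2C[C@@H]2c2ccc(OCc3c(-c4c(Cl)cccc4Cl)noc3C3CC3)cc2Cl)c1` gives 101%

Compound 1 stands level with compound 3, and its gap to compound 2 lies within the scatter, so all three sit together on the read-out of largest response. Compound 4 `CC(C)n1nc(C(=O)O)cc1C1CC1c1ccc(OCc2c(-c3c(Cl)cccc3Cl)noc2C2CC2)cc1Cl` differs from compound 1 by 3-carboxy-1-isopropyl-1H-pyrazol-5-yl in place of 6-carboxypyridin-3-yl on a saturated ring carbon. Among the compounds with values here, the one measured step that bears on this is no change at the digits printed from compound 1 to compound 3 (within the scatter), where the carboxy-bearing aromatic ring on a saturated ring carbon of the three-membered ring was exchanged and the maximal response stayed put. The exchange leading to compound 4 is of the same kind, one aromatic acid replaced by another at that place. Compound 4 is therefore expected to show a step of a number 2 percentage points lower from compound 1 to compound 4 (within the scatter), nothing beyond the scatter. The estimate for compound 4 is 99%, within 88% to 108%.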

Compound 4, largest response reached (reported as efficacy), in percent of the reference or control that the assay uses: 102%
Compound 4: the middle estimate sits 3 percentage points below what was measured; the range from low to high includes it.
By their numbers in this assay, from the lowest: compounds 2, 1, 3 and 4 (each within the scatter of the next).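

In this assay, the exchange gives a number 1 percentage points higher from compound 1 to compound 4 (within the scatter). The earlier step compared only six-membered aromatic rings at this place, whereas 3-carboxy-1-isopropyl-1H-pyrazol-5-yl brings a five-membered aromatic ring with an isopropyl group, and the maximal response stays within the scatter. No evidence here gives a reason for this result. Every compound shown carries a carboxylic acid, so it remains open how a tetrazole or an amide would fare in its place. Largest response alone also leaves open how much compound is needed to reach it.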